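From methyl to chloro on compound 3

A few compounds are considered here, and "the series" means these few. Any claim that something is new, unique, unknown or untested is made for them only; others in the source may bear on it.

In a functional assay on 4T1 cells (Homo sapiens) for cytotoxicity, read by MTT assay, with a stated time of 48 h (a lower number here means a stronger inhibitor, a higher number a weaker inhibitor), compound 3 (`CCn1c(/C=C2/C(=O)Nc3ccc(C)cc32)nc2ccccc21`) gives 39400 nM as its value. That lies within the scatter of compound 2 (`CC(C)n1c(/C=C2/C(=O)Nc3ccccc32)nc2ccccc21`) at 40400 nM and clearly above compound 1 (`CC(C)n1c(/C=C2/C(=O)Nc3ccc(Br)cc32)nc2ccccc21`) at 5960 nM on the same scale.

Compound 4 (`CCn1c(/C=C2/C(=O)Nc3ccc(Cl)cc32)nc2ccccc21`) differs from compound 3 by chloro in place of methyl on an aromatic carbon. Among the compounds with values here, no measured step runs from methyl to a halogen. The nearest evidence is a swap of hydrogen in place of bromo, which involves neither chloro nor methyl. Compounds 1 and 2 also differ from compound 3 elsewhere on the shared core, so this is only a loose guide. Because a 6.8-fold higher number from compound 1 to compound 2 (0.83 log units; beyond the scatter) came with the loss of bromo, a smaller step the other way is expected in this assay when chloro enters. The expected change is a 3.0-fold lower number from compound 3 to compound 4 (0.48 log units; beyond the scatter) in this estimate. For compound 4 the estimated value is 13000 nM with a likely range from 4500 nM to 40000 nM around it.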

Compound 4, half-maximal inhibitory concentration: > 50000 nM
Compound 4: a limit, no number; the forecaster's own chance of this, stated with the estimate: 3%; at least 3.8-fold (0.58 log units) between middle value and limit.
By their numbers in this assay, from the lowest: compound 1; then compounds 3 and 2 (each within the scatter of the next). At a limit, above all of these: compound 4.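

In this assay compound 4 reaches only a limit of the assay, not a number: the limit of > 50000 nM in this assay, at which 1 of the 4 values shown sits. As far as these compounds go, the step is an at least 1.2-fold higher number from compound 3 to compound 4 (0.10 log units; that floor lies within the scatter), so the true size of this change stays unknown, and putting chloro in place of methyl on this aromatic carbon gives no lower number. Carrying a halogen at this place is therefore not enough on its own: bromo goes with the lower number in a 6.8-fold higher number from compound 1 to compound 2 (0.83 log units; beyond the scatter), but compound 4, with chloro, goes against any general halogen pattern.

Still open, from the compounds shown here alone, is how an amine or a methoxy group at this place on the core of compound 3 would read in this assay. Also open, going by these compounds, is whether bromo on that same core would give a measurable number rather than another limit.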